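The compounds below may be only part of what the source reports. "The series", "measured", "known", "first", "only" and "open" are said of these compounds alone.

Three compounds share one core. In an assay (Cricetulus griseus) for inhibition of aldehyde dehydrogenase, mitochondrial (Homo sapiens) (on this read-out higher numbers stand for weaker inhibition and lower numbers for stronger inhibition), compound 3 `O=c1c(-c2ccc(O)cc2)coc2cc(OCCCCCCO)ccc12` gives 120 nM, the lowest of the three numbers; compound 2 `CCOC(=O)CCCCOc1ccc2c(=O)c(-c3ccc(O)cc3)coc2c1` gives 240 nM, and compound 1 `O=c1c(-c2ccc(O)cc2)coc2cc(OCCCCCCCCCO)ccc12` gives 700 nM. Compound 4 `O=c1c(-c2ccc(O)cc2)coc2cc(OCCCCCCCCCCCCO)ccc12` carries 6-hydroxyhexyl in place of hydroxy on a saturated chain carbon, six bonds along the chain from an oxygen on an aromatic ring. The measured step most like this change is a 5.8-fold lower number from compound 1 to compound 3 (0.77 log units; beyond the scatter), where the shorter chain went with the lower number; compound 4 runs the other way, to a longer chain than either. The steps of a 2.9-fold lower number from compound 1 to compound 2 (0.46 log units; beyond the scatter) and a 2.0-fold lower number from compound 2 to compound 3 (0.30 log units; within the scatter) alter the chain end rather than its length and bear less on it. One therefore expects the number for compound 4 to rise beyond the scatter, a 17-fold higher number from compound 3 to compound 4 (1.22 log units; beyond the scatter), to an estimated 2000 nM, within 500 nM to 8000 nM.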

Compound 4, half-maximal inhibitory concentration: 1700 nM
Compound 4: the middle estimate sits 1.2-fold (0.07 log units) above what was measured; the range from low to high includes it.
By their numbers in this assay, from the lowest: compounds 3 and 2 (each within the scatter of the next); then compound 1; then compound 4.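

In this assay the chain keeps answering to added length well past compound 1 (a 2.4-fold higher number from compound 1 to compound 4 (0.39 log units; beyond the scatter)), and 6-hydroxyhexyl in place of hydroxy gives the largest step in the series (a 14-fold higher number from compound 3 to compound 4 (1.15 log units; beyond the scatter)). Among the hydroxy-ended chains the number therefore rises with each lengthening, through compounds 3, 1 and 4, while the ethoxycarbonyl-ended compound 2 stands outside that run (a 7.1-fold higher number from compound 2 to compound 4 (0.85 log units; beyond the scatter)). Nothing available explains this rise. Still open, on these data alone, is whether a chain shorter than that of compound 3 would lower the number further. Also open, as far as these compounds go, is how an amine or a carboxylic acid would compare with hydroxy at the chain end.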